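Amine exchange on the aryl ether oxygen of compound 3

The source may report more compounds than this note shows. Statements on the series, on what has been measured and on what is new or still open speak of the compounds shown alone.

In an assay on HEK293 cells for displacement of a labelled ligand from melanin-concentrating hormone receptor 1 (Homo sapiens) (a higher number here means a weaker inhibitor, a lower number a stronger inhibitor), compound 3 `COc1cc(NC(=O)c2ccc(C3CCCCC3)cc2)ccc1OC12CCCN(CC1)C2` gives 50.1 nM, the lowest of the three numbers, with compound 1 `COc1cc(NC(=O)c2ccc(C3CCCCC3)cc2)ccc1OC1CCN(C)C1` at 63.1 nM within the scatter of it. Compound 2 `COc1cc(NC(=O)c2ccc(C3CCCCC3)cc2)ccc1O[C@H]1CCCC[C@@H]1N(C)C` gives 2510 nM. Compound 4 `CCN1CCN(Oc2ccc(NC(=O)c3ccc(C4CCCCC4)cc3)cc2OC)CC1` carries a group of 8 heavy atoms (6 carbon, 2 nitrogen; one six-membered non-aromatic ring with 2 hetero atoms) in place of a group of 8 heavy atoms (7 carbon, 1 nitrogen; one five-membered non-aromatic ring with 1 hetero atom, one six-membered non-aromatic ring with 1 hetero atom), on an oxygen on an aromatic ring. Two kinds of measured step bear on this. The step of a 1.3-fold lower number from compound 1 to compound 3 (0.10 log units; within the scatter) shows that swapping one cyclic amine for another on this oxygen need not move the number, whereas a 40-fold higher number from compound 1 to compound 2 (1.60 log units; beyond the scatter) and a 50-fold lower number from compound 2 to compound 3 (1.70 log units; beyond the scatter) show that the amine group can move it a long way. For compound 4 a step of a 5.0-fold higher number from compound 3 to compound 4 (0.70 log units; beyond the scatter) in this assay is therefore expected, most likely toward a higher number, with wide uncertainty. Compound 4 is estimated at 250 nM, with a range of 50 nM to 1250 nM.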

Compound 4, inhibition constant: 79.4 nM
The estimate for compound 4 lay 3.1-fold (0.50 log units) above the measured number, within the range that was stated.
By their numbers in this assay, from the lowest: compounds 3, 1 and 4 (each within the scatter of the next); then compound 2.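

In this assay, 4-ethylpiperazin-1-yl on this oxygen stays within the scatter of both earlier cyclic amines, with a 1.6-fold higher number from compound 3 to compound 4 (0.20 log units; within the scatter) and a 1.3-fold higher number from compound 1 to compound 4 (0.10 log units; within the scatter). A ring carrying 2 nitrogens therefore fits with compound 1 and compound 3, while compound 2 remains the exception, with a 32-fold lower number from compound 2 to compound 4 (1.50 log units; beyond the scatter). No measurement at hand explains why these three groups read alike.

Still open, going by these compounds, is whether a morpholine or an open-chain 2-(dimethylamino)ethyl group on this oxygen would stay with compound 1, compound 3 and compound 4 or fall toward compound 2.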